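A few compounds are considered here, and "the series" means these few. Any claim that something is new, unique, unknown or untested is made for them only; others in the source may bear on it.

Measured compounds:
compound 1 `C=C(Br)C(=O)Nc1cccc(/C=C2\SC(=O)N(Cc3ccc(Cl)cc3)C2=O)c1`, 1400 nM
compound 2 `C=C(Br)C(=O)Nc1ccc(/C=C2\SC(=O)N(Cc3cccc(Cl)c3)C2=O)cc1`, 3700 nM
compound 3 `Nc1cccc(/C=C2\SC(=O)N(Cc3cccc(F)c3)C2=O)c1`, 250000 nM

In a functional assay on CCRF-CEM cells (Homo sapiens) for cytotoxicity, read by cell counting, with a stated time of 3 days (a higher number here means a weaker inhibitor, a lower number a stronger inhibitor), compound 1 gives the lowest of the three numbers. Compound 2 lies beyond the scatter above it, and compound 3 lies far higher still, beyond the scatter by a wide margin. Compound 4 `C=C(Br)C(=O)Nc1cccc(/C=C2\SC(=O)N(Cc3cccc(Cl)c3)C2=O)c1` has not been measured in this assay. It differs from compound 1 in one place: 3-chlorophenyl in place of 4-chlorophenyl on a saturated chain carbon bound to an amide-type nitrogen in a ring. Going by the values given here, no step between two measured compounds isolates this change, so the expectation rests on the standing of compound 1 alone. The step from compound 1 to compound 4 is expected to be small, a 1.3-fold higher number from compound 1 to compound 4 (0.11 log units; within the scatter), most likely within the scatter. Compound 4 is therefore estimated at 1800 nM, with a range from 700 nM to 4500 nM.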

Compound 4, half-maximal inhibitory concentration: 1400 nM
Beside the measured number, compound 4's estimate is 1.3-fold (0.11 log units) above it; the measured number falls inside the stated range.
By their numbers in this assay, from the lowest: compounds 1 and 4 (each within the scatter of the next); then compound 2; then compound 3.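

In this assay, going by these compounds alone, 3-chlorophenyl in place of 4-chlorophenyl, on a saturated chain carbon bound to an amide-type nitrogen in a ring, gives no change at the digits printed from compound 1 to compound 4 (within the scatter) and is the first one-place comparison at this position. For this pair, the number does not distinguish the two chlorophenyl groups. No measurement shown explains this result.

The compounds shown leave open whether the number would hold with a methoxy or trifluoromethyl group in place of chlorine on the phenyl ring. They also leave open the effect of a longer chain between the phenyl ring and the ring nitrogen.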